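Sulfonyl aryl swap in a cytotoxicity series

The source may hold more compounds than are shown below. What is called first, only, known or untested is meant among the compounds shown, and "the series" means these compounds.

Compound 1 `CC1(c2ccc(-c3cccc(/C(N)=N\O)c3)cc2)CC(S(=O)(=O)c2ccc(F)cc2)=C(c2ccc(/C(N)=N\O)cc2)O1`: 11000 nM
Compound 2 `CC1(Cc2ccccc2)CC(S(=O)(=O)c2cccc(F)c2)=C(c2ccc(/C(N)=N\O)cc2)O1`: 28300 nM
Compound 3 `COc1cc(-c2ccc(C3(C)CC(S(=O)(=O)c4ccc(F)cc4)=C(c4ccc(/C(N)=N\O)cc4)O3)cc2)cc(OC)c1OC`: 5220 nM

In an ADME assay on J774.A1 cells (Mus musculus) for cytotoxicity, read by MTT assay, with a stated time of 72 h (on this read-out lower numbers stand for higher toxicity in this test and higher numbers for lower toxicity in this test), compound 2 gives the highest of the three numbers; compound 1 sits nearer to it and compound 3 furthest away, both steps beyond the scatter. Compound 4 `CC1(Cc2ccccc2)CC(S(=O)(=O)c2ccccc2C(F)(F)F)=C(c2ccc(/C(N)=N\O)cc2)O1` differs from compound 2 in one place: 2-(trifluoromethyl)phenyl in place of 3-fluorophenyl on a sulfonyl sulfur. Among the measured compounds shown here, the only measured step, a 2.1-fold lower number from compound 1 to compound 3 (0.32 log units; beyond the scatter), concerns the aromatic group on the ring carbon, not the sulfonyl aryl, so no measured step bears directly on this change. Compound 4 is therefore expected to show no step beyond the scatter, a 1.1-fold lower number from compound 2 to compound 4 (0.05 log units; within the scatter). The value of compound 4 is estimated at 25000 nM, with a range from 10000 nM to 60000 nM.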

Compound 4, half-maximal cytotoxic concentration: 23500 nM
Compound 4: the middle estimate sits 1.1-fold (0.03 log units) above what was measured; the measured number falls inside the stated range.
By their numbers in this assay, from the lowest: compound 3; then compound 1; then compounds 4 and 2 (each within the scatter of the next).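

In this assay, among the compounds shown here, this is the first step read at the aryl group on the sulfonyl sulfur, and 2-(trifluoromethyl)phenyl in place of 3-fluorophenyl gives a 1.2-fold lower number from compound 2 to compound 4 (0.08 log units; within the scatter). The entering group has 10 heavy atoms against 7, yet the two numbers cannot be told apart at this position. Nothing available accounts for this result.

Still open, going by these compounds, is whether an amine or a carboxylic acid in place of trifluoromethyl would also stay within the scatter. Whether this swap would behave the same on the core of compound 1 or compound 3 is also unresolved.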